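A few compounds are considered here, and "the series" means these few. Any claim that something is new, unique, unknown or untested is made for them only; others in the source may bear on it.

Measured in a functional assay on A-431 cells (Homo sapiens) for cytotoxicity, read by resazurin assay; a higher number here means a weaker inhibitor, a lower number a stronger inhibitor:
- compound 1 `C#Cc1cccc(Nc2ncnc3cc(NC(=O)c4ccc(C(=O)Nc5ccccc5N)cc4)ccc23)c1` gives 1600 nM
- compound 2 `C#Cc1cccc(Nc2ncnc3ccc(NC(=O)c4ccc(C(=O)Nc5ccccc5N)s4)cc23)c1` gives > 16000 nM (a limit, not a number)
- compound 3 `C#Cc1cccc(Nc2ncnc3ccc(OCc4ccc(C(=O)Nc5ccccc5N)cc4)cc23)c1` gives 1600 nM
- compound 4 `Nc1ccccc1NC(=O)c1ccc(COc2ccc3ncnc(Nc4cccc(Br)c4)c3c2)cc1` has not yet been measured

Compound 3 stands at 1600 nM, level with compound 1 at 1600 nM within the usual scatter. Compound 2 gives only a limit, so it offers no number for comparison.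

Compound 4 keeps the rest of compound 3 and carries bromo in place of ethynyl on an aromatic carbon, meta to a large group (bromo in place of ethynyl on an aromatic carbon). Among the measured compounds shown here, no pair of measured compounds tests this change, so the expectation rests on compound 3 at 1600 nM alone. No step beyond the scatter is expected in this assay, and no direction is favoured. The estimated change is no change at the digits printed from compound 3 to compound 4 (within the scatter). For compound 4 the expected value is 1600 nM, with an estimated range from 550 nM to 5000 nM.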

Compound 4, half-maximal inhibitory concentration: 1700 nM
Beside the measured number, compound 4's estimate is 1.1-fold (0.03 log units) below it, within the range that was stated.
By their numbers in this assay, from the lowest: compounds 1, 3 and 4 (each within the scatter of the next). At a limit, above all of these: compound 2.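

In this assay, bromo in place of ethynyl on the aromatic carbon gives a 1.1-fold higher number from compound 3 to compound 4 (0.03 log units; within the scatter). Among the compounds shown here, this is the first comparison between compounds that differ in one place, and it shows that at this position, meta to a large group, the two-carbon ethynyl with its triple bond and the single bromine atom read alike within the scatter. Nothing measured here gives a cause for this result.

The compounds shown carry only ethynyl and bromo at this position, so how a methoxy group, an amine or a carboxylic acid would read there remains open. Going by these compounds, whether the same change would read alike on compound 1, which has a different link to the shared core, also remains open.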